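Cyclopropyl for methyl on the amine of compound 2

The compounds below may be only part of what the source reports. "The series", "measured", "known", "first", "only" and "open" are said of these compounds alone.

Two members of the series have numbers in an assay on isolated protein for binding affinity to adenosine receptor A1 (Bos taurus); a lower number here means a stronger inhibitor, a higher number a weaker inhibitor. Compound 1 `Clc1ccccc1Cn1nnc2c(NC3CC3)nc(-c3ccccc3)nc21` gives 11000000 nM in this assay. Compound 2 `CNc1nc(-c2ccccc2)nc2c1nnn2Cc1ccccc1` gives 353000000 nM in this assay, the highest of the two numbers; its nearest neighbour is compound 1, whose lower number lies beyond the scatter. Among the measured compounds shown here, no step between the two measured compounds rests on a single change, so no measured step is on hand.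

Compound 3 `c1ccc(Cn2nnc3c(NC4CC4)nc(-c4ccccc4)nc32)cc1` has not been measured. It differs from compound 2 in one place: cyclopropyl in place of methyl on a nitrogen on an aromatic ring. Compound 1 also carries cyclopropylamino and shows the lower of the two numbers, so the change is expected to lower the number in this assay by a step beyond the scatter rather than leave it unchanged. The step from compound 2 to compound 3 is estimated as an 18-fold lower number from compound 2 to compound 3 (1.25 log units; beyond the scatter). For compound 3 the expected value in this assay is 20000000 nM, with a range from 4000000 nM to 100000000 nM.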

Compound 3, inhibition constant: 11000000 nM
Compound 3: middle estimate off by 1.8-fold (0.26 log units), on the high side; the measured number falls inside the stated range.
By their numbers in this assay, from the lowest: compounds 1 and 3 (each within the scatter of the next); then compound 2.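

In this assay, cyclopropyl in place of methyl on a nitrogen on an aromatic ring now stands as an isolated single change: it gives a 32-fold lower number from compound 2 to compound 3 (1.51 log units; beyond the scatter) and is a large step, which the two earlier compounds, differing in more than one place, could not separate from the chloro group. Hydrogen in place of chloro on an aromatic carbon gives no change at the digits printed from compound 1 to compound 3 (within the scatter) in the same assay, so with cyclopropylamino present the chloro group shifts the number by nothing beyond the scatter, and the difference seen earlier tracks the methylamino to cyclopropylamino change in this small set. No supporting measurement accompanies either step.

On these data alone, whether cyclobutyl, a longer chain such as propyl, or an unsubstituted amine on the same nitrogen would read like cyclopropyl or like methyl remains open. Also open, as far as these compounds go, is whether the methylamino to cyclopropylamino step keeps its size with chloro present, and whether fluoro or methoxy in place of chloro would leave the number as unmoved as hydrogen does.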